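Aryl ether variation and microsomal half-life in the series

The source may report more compounds than this note shows. Statements on the series, on what has been measured and on what is new or still open speak of the compounds shown alone.

Compound 1 `C=CC(=O)NCc1coc(-c2c(N)ncnc2Nc2ccc(OCc3cccc(F)c3)c(Cl)c2)n1` gives 0.75 h in an in vitro ADME assay on microsomes from liver (Homo sapiens) for metabolic stability, tested at 5 uM; on this read-out lower numbers stand for a shorter-lived compound and higher numbers for a longer-lived compound. Compound 2 `C=CC(=O)NCc1coc(-c2c(N)ncnc2Nc2ccc(Oc3ccccc3)c(Cl)c2)n1` reaches only the assay limit of > 1.66 h in this assay. Compound 3 `C=CC(=O)NCc1coc(-c2c(N)ncnc2Nc2ccc(Oc3cc(Cl)ccc3Cl)c(Cl)c2)n1` gives 1.6 h in this assay; of the two numbers shown it stands highest, with compound 1 nearest, through a 2.1-fold higher number from compound 1 to compound 3 (0.33 log units; beyond the scatter). The other ether variations read an at least 2.2-fold higher number from compound 1 to compound 2 (0.34 log units; beyond the scatter) and an at least 1.0-fold lower number from compound 2 to compound 3 (0.01 log units; that floor lies within the scatter), the latter within the scatter.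

Compound 4 `C=CC(=O)NCc1coc(-c2c(N)ncnc2Nc2ccc(Oc3cccc(F)c3)c(Cl)c2)n1` differs from compound 3 by 3-fluorophenyl in place of 2,5-dichlorophenyl on an oxygen on an aromatic ring. The step that bears most on it is the one between the two aryl ethers already measured, from compound 2 to compound 3, which stayed within the scatter, whereas the steps from the benzyl ether of compound 1 were modest. No step beyond the scatter is therefore expected in this assay. Compound 4 is expected to show a 1.1-fold lower number from compound 3 to compound 4 (0.03 log units; within the scatter). The value expected for compound 4 is 1.5 h, within 0.8 h to 2.5 h. One of the three measured values already sits at the limit of > 1.66 h in this assay, at which 1 of the 3 values shown sits, so a limit rather than a number remains possible for compound 4.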

Compound 4, half-life: > 1.66 h
Compound 4: only a limit was reported; the forecaster's own chance of this, stated with the estimate: 40%; middle value at least 1.1-fold (0.04 log units) from the limit.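

A third aryl group on this oxygen, 3-fluorophenyl, again separates from the 3-fluorobenzyl ether, with an at least 2.2-fold higher number from compound 1 to compound 4 (0.34 log units; beyond the scatter); phenyl and 2,5-dichlorophenyl did the same, so all the aryl ethers shown stand beyond the scatter against the benzyl ether. Replacing 2,5-dichlorophenyl with 3-fluorophenyl gives an at least 1.0-fold higher number from compound 3 to compound 4 (0.01 log units; that floor lies within the scatter), so this change of ring substituents shows no readable difference in this assay. The step from compound 2 to compound 4 cannot be read, and the aryl ethers now run into a limit of the assay rather than a number: the limit of > 1.66 h in this assay, at which 2 of the 4 values shown sit.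

From the compounds shown here alone, how far compound 2 and compound 4 lie past that limit stays open, so no order among the aryl ethers can be drawn. Also open, going by these compounds, is what an aminomethyl group or a carboxylic acid on the phenyl ring would do to the half-life.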